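Compound 3: removing the fluoro from compound 1

A few compounds are considered here, and "the series" means these few. Any claim that something is new, unique, unknown or untested is made for them only; others in the source may bear on it.

In a functional assay on Bel-7402 cells (Homo sapiens) for antiproliferative activity, read by MTT assay, with a stated time of 72 h (on this read-out higher numbers stand for weaker inhibition and lower numbers for stronger inhibition), compound 1 (`COc1cccc(CNCc2c(C(=O)O)n(Cc3ccccc3F)c3cc(C)ccc23)c1`) gives > 50000 nM, which is a limit of the assay and not a number. Compound 2 (`COc1cccc(CNCc2c(C(=O)O)n(Cc3ccccc3F)c3cc(C(C)C)ccc23)c1`) gives 5590 nM in this assay. Compound 3 (`COc1cccc(CNCc2c(C(=O)O)n(Cc3ccccc3)c3cc(C)ccc23)c1`) departs from compound 1 by hydrogen in place of fluoro on an aromatic carbon, or 2-fluorobenzyl to benzyl. Going by the values given here, the only measured step, an at least 8.9-fold lower number from compound 1 to compound 2 (0.95 log units; beyond the scatter), is isopropyl in place of methyl, a change at another place. Among the compounds with values here, it therefore bears only indirectly, and no measured step tests the fluoro itself. Without such evidence, no step beyond the scatter is expected in this assay, and no direction can be favoured. The expected step is a step that the limit leaves unreadable from compound 1 to compound 3. Another report as a limit is also quite likely. For compound 3 the estimated value is 60000 nM, with an expected range of 25000 nM to 150000 nM.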

Compound 3, half-maximal inhibitory concentration: 12500 nM
The estimate for compound 3 lay 4.8-fold (0.68 log units) above the measured number, and the stated range ends above it.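

In this assay, hydrogen in place of fluoro on an aromatic carbon gives an at least 4.0-fold lower number from compound 1 to compound 3 (0.60 log units; beyond the scatter). Going by these compounds alone, this is the first direct reading at this position, ortho to a large group: the fluoro is not required for inhibition here, and the benzyl side of the molecule, like the place of the methyl-to-isopropyl change, moves the read-out. The step has only a lower bound on its size, and for compound 1 the value is a limit and not a number: the limit of > 50000 nM in this assay, at which 1 of the 3 values shown sits.

The compounds shown do not tell whether the fluoro itself is unfavourable or whether chloro, methoxy or a nitrile on this carbon would read the same. Going by these compounds, whether 2-fluorobenzyl to benzyl would also lower the number when isopropyl replaces the methyl of the core remains open.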